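A few compounds are considered here, and "the series" means these few. Any claim that something is new, unique, unknown or untested is made for them only; others in the source may bear on it.

Compound 1 `N#C/N=C1\N(CCCCCOc2ccc(Cl)cc2)C(=O)CN1c1ccncc1` gives 5360 nM.
Compound 2 `N#C/N=C1\N(CCCCCCOc2ccc(Cl)cc2)C(=O)CN1c1ccncc1` gives 443 nM.
Compound 3 `N#C/N=C1\N(CCCCCCCOc2ccc(Cl)cc2)C(=O)CN1c1ccncc1` gives 815 nM.

In a functional assay on MCF7 cells (Homo sapiens) for cytotoxicity (a lower number here means a stronger inhibitor, a higher number a weaker inhibitor), compound 1 stands with the highest number of the three, which means it is the weakest of the measured compounds. The nearest to it is compound 3, with a 6.6-fold lower number from compound 1 to compound 3 (0.82 log units; beyond the scatter); the furthest is compound 2, with a 12-fold lower number from compound 1 to compound 2 (1.08 log units; beyond the scatter). Between the two stronger compounds the difference is small, a 1.8-fold higher number from compound 2 to compound 3 (0.26 log units; within the scatter), so those two cannot be told apart on these numbers.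

Compound 4 `CC1C(=O)N(CCCCCOc2ccc(Cl)cc2)/C(=N\C#N)N1c1ccncc1` is built from compound 1 by a single change: methyl in place of hydrogen on a saturated ring carbon. All three measured steps concern a different part of the molecule, namely the length of the chain that carries the 4-chlorophenoxy group, and none of them changes anything on the ring carbon where the methyl now enters. For the measured compounds named here, there is thus no measured step that bears directly on this change, and the expectation has to rest on compound 1 itself. On that basis the step from compound 1 to compound 4 is expected to stay within the scatter, in no clear direction, namely a 1.1-fold lower number from compound 1 to compound 4 (0.03 log units; within the scatter). Compound 4 is therefore estimated at 5000 nM, with a range from 1500 nM to 16000 nM.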

Compound 4, half-maximal inhibitory concentration: 9260 nM
Compound 4: the middle estimate sits 1.9-fold (0.27 log units) below what was measured; the measured number falls inside the stated range.
By their numbers in this assay, from the lowest: compounds 2 and 3 (each within the scatter of the next); then compounds 1 and 4 (each within the scatter of the next).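

In this assay, methyl in place of hydrogen on this saturated ring carbon gives a 1.7-fold higher number from compound 1 to compound 4 (0.24 log units; within the scatter), so on these numbers compound 1 and compound 4 cannot be told apart. For the compounds shown here, this is the first reading at this ring position, and it shows that adding this one carbon to the core of compound 1 leaves no change that can be separated from ordinary assay variation, unlike the chain step that gave a 12-fold lower number from compound 1 to compound 2 (1.08 log units; beyond the scatter). No available evidence accounts for this result.

From the compounds shown here alone, the effect of a larger group at this ring carbon, such as an ethyl or a phenyl, or of a second methyl on the same carbon, remains open. Going by these compounds, it is also open whether the methyl would give a similar result with the chain of compound 2 or compound 3, since only its step on the chain of compound 1 can be read here.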